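Iodo in place of chloro on the benzylic aryl of compound 3

A few compounds are considered here, and "the series" means these few. Any claim that something is new, unique, unknown or untested is made for them only; others in the source may bear on it.

Compound 3 `O=c1cc(CNCc2ccc(Cl)cc2)oc2ccc(O)c(O)c12` carries a 4-chlorophenyl group on the saturated chain carbon bound to the amine nitrogen. In an ADME assay on Huh-7 cells (Homo sapiens) for cytotoxicity (on this read-out higher numbers stand for lower toxicity in this test and lower numbers for higher toxicity in this test), compound 3 gives only a limit, > 100000 nM. Compound 1 `O=c1cc(CNCc2cccc(O)c2)oc2ccc(O)c(O)c12` bears a 3-hydroxyphenyl group at that place. In this assay compound 1 also gives only a limit, > 100000 nM. Compound 2 `Cc1cccc(CNCc2cc(=O)c3c(O)c(O)ccc3o2)c1` bears a 3-methylphenyl group there. For compound 2 this assay again reports only a limit, > 100000 nM. The steps among them (a step that the two limits leave unreadable from compound 1 to compound 2, a step that the two limits leave unreadable from compound 1 to compound 3 and a step that the two limits leave unreadable from compound 2 to compound 3) cannot be sized, because of the limit of > 100000 nM in this assay, at which 3 of the 3 values shown sit. Compound 4 `O=c1cc(CNCc2ccc(I)cc2)oc2ccc(O)c(O)c12` differs from compound 3 by iodo in place of chloro on an aromatic carbon. The two steps that exchange the aryl group on the chain carbon and end at compound 3 are the ones that bear on this change, and both are hidden by the limit. Compound 4 is therefore expected to stay near that limit, with an expected step that the limit leaves unreadable from compound 3 to compound 4. The estimate for compound 4 is 120000 nM, within 40000 nM to 400000 nM.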

Compound 4, half-maximal cytotoxic concentration: 41700 nM
Beside the measured number, compound 4's estimate is 2.9-fold (0.46 log units) above it; low and high end bracket the measured number.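

In this assay, compound 4 is the only one of the four compounds shown that comes off the limit: the limit of > 100000 nM in this assay, at which 3 of the 4 values shown sit. Iodo in place of chloro gives an at least 2.3-fold lower number from compound 3 to compound 4 (0.37 log units; beyond the scatter), so this place on the ring, para to a large group, is the first shown to register a change in the read-out, here towards higher toxicity. The 4-iodophenyl group gives the same kind of result against the other aryl groups on the chain carbon, with an at least 2.3-fold lower number from compound 2 to compound 4 (0.37 log units; beyond the scatter) and an at least 2.3-fold lower number from compound 1 to compound 4 (0.37 log units; beyond the scatter).

As far as these compounds go, all three steps have only a lower bound, so their full size remains unknown. The compounds shown also leave open whether the shift is specific to iodo, and a bromo, a methoxy or an amine at this place would test that.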